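Ring swap at the biaryl position: compound 2 to compound 4

The source may report more compounds than this note shows. Statements on the series, on what has been measured and on what is new or still open speak of the compounds shown alone.

Measured compounds:
compound 1, `Cn1nc2c(=O)n(CC3(O)CCN(Cc4ccc(-c5ccncc5)cc4Cl)CC3)cnc2c1-c1ccc(CN)cc1`: 257 nM
compound 2, `Cn1nc2c(=O)n(CC3(O)CCN(Cc4ccc(-c5ccsc5)cc4Cl)CC3)cnc2c1-c1ccc(CN)cc1`: 59.5 nM
compound 3, `Cn1nc2c(=O)n(CC3(O)CCN(Cc4ccc(-c5ccco5)cc4Cl)CC3)cnc2c1-c1ccc(CNC=O)cc1`: 20.9 nM

All three numbers come from an assay on isolated protein for inhibition of ubiquitin carboxyl-terminal hydrolase 7 (Homo sapiens), with stated times of 30 min and 2 h; on this read-out higher numbers stand for weaker inhibition and lower numbers for stronger inhibition. Compound 2 stands second highest of the three: compound 3 sits lower, compound 1 higher, and both gaps are beyond the scatter. Going by the values given here, the one single-point step among the measured compounds is a 4.3-fold lower number from compound 1 to compound 2 (0.64 log units; beyond the scatter), a modest move that followed exchange of one five-membered aromatic ring for another at the same place.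

The next compound, compound 4, is `Cn1nc2c(=O)n(CC3(O)CCN(Cc4ccc(-c5ccc(C(=O)O)o5)cc4Cl)CC3)cnc2c1-c1ccc(CN)cc1`. It differs from compound 2 in one place:
5-carboxyfuran-2-yl in place of thiophen-3-yl on an aromatic carbon

Among the compounds with values here, only the step from compound 1 to compound 2 bears on this change, and it concerns the same position of the shared core. Compound 3 carries a furan at that position, but it also differs from compound 2 at the distal amine, so its number cannot be read as a clean comparison. Within the data shown here, the carboxylic acid on the entering ring has no precedent in this set. A step in this assay near a 1.3-fold higher number from compound 2 to compound 4 (0.13 log units; within the scatter) is therefore expected, with no direction called beyond the scatter and a wide range around it. Compound 4 is estimated at 80 nM, between 25 nM and 260 nM.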

Compound 4, half-maximal inhibitory concentration: 753 nM
Compound 4: the middle estimate sits 9.4-fold (0.97 log units) below what was measured; the measured number lies above the stated range.
By their numbers in this assay, from the lowest: compound 3; then compound 2; then compound 1; then compound 4.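

At this place, para to a large group and meta to a chloro group, the ring is not freely exchangeable in this assay: the change brings a 13-fold higher number from compound 2 to compound 4 (1.10 log units; beyond the scatter), a large step where the earlier exchange of rings gave a modest one. The number also rises relative to the pyridin-4-yl ring, with a 2.9-fold higher number from compound 1 to compound 4 (0.47 log units; beyond the scatter), so the three groups carried on otherwise identical structures now stand in a clear order, with thiophen-3-yl giving the lowest number, pyridin-4-yl the next and 5-carboxyfuran-2-yl the highest. No measurement in hand accounts for this order or for the size of the rise.

The data do not separate the furan ring from the carboxylic acid in this step. Compound 3 carries a furan but also differs from compound 2 at the distal amine. A methyl ester or a primary amide in place of the carboxylic acid on the same furan, or a carboxylic acid placed on the thiophene, would bear directly on that question.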